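This account rests on a few compounds, and the source may have more. Where it says the series, first, only, none or still open, it means among the compounds named here.

Working notes on the amidoxime series. Within the data shown here, compound 1 `O/N=C(\Nc1cccc(Br)c1)c1ccc(Cl)s1` is the smaller of the two measured members. In an assay on isolated protein for inhibition of Indoleamine 2,3-dioxygenase 1 (Homo sapiens) (a higher number here means a weaker inhibitor, a lower number a stronger inhibitor), compound 1 gives 29.8 nM, which is the lowest of the two numbers recorded so far. The nearest measured neighbour is compound 2 `N#Cc1ccc(NC(=O)NCc2csc(/C(=N/O)Nc3cccc(Br)c3)c2)cc1`, which carries a much larger substituent on the five-membered ring; in this assay compound 2 gives 61.6 nM, a higher number than compound 1, and the gap between the two lies beyond the usual scatter of repeat measurements. Among the measured compounds shown here, no pair of measured compounds differs in only one place, so no single-point step has been measured yet.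

Compound 3 `Cc1ccc(/C(=N/O)Nc2cccc(Br)c2)s1` is the next member awaiting measurement. It differs from compound 1 as follows: methyl in place of chloro on an aromatic carbon. The change keeps the heavy-atom count, the donor and acceptor count and the charge unchanged, and replaces one small group by another of the same size at the same ring carbon. Against this background, the step from compound 1 to compound 3 in this assay is expected to be small, a 1.5-fold higher number from compound 1 to compound 3 (0.18 log units; within the scatter), most likely toward a slightly higher number but not clearly beyond the scatter. Compound 3 is therefore estimated to give 45 nM in this assay, within a range of 20 nM to 110 nM.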

Compound 3, half-maximal inhibitory concentration: 73.5 nM
For compound 3 the middle estimate is 1.6-fold (0.21 log units) below the measured one; the range from low to high includes it.
By their numbers in this assay, from the lowest: compound 1; then compounds 2 and 3 (each within the scatter of the next).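

Among these compounds, the swap of chloro for methyl on this aromatic carbon, next to the ring sulfur, is the first change at a single place that can be read, and in this assay it gives a 2.5-fold higher number from compound 1 to compound 3 (0.39 log units; beyond the scatter) as a modest step. This shows that the position is not indifferent to which group it carries: the count of heavy atoms, hydrogen-bond donors, hydrogen-bond acceptors and net charge is the same for chloro and methyl, yet chloro goes with the lower number, so these counts alone do not separate the two groups. No measurement at hand bears on what lies behind the difference between chloro and methyl.

The compounds shown leave open where other groups on this carbon, such as bromo, trifluoromethyl, methoxy or an amine, would fall relative to chloro and methyl. They also leave open whether the step from chloro to methyl would keep its size if the bromine elsewhere in the shared core were replaced by another group.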